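Hydrazone aryl exchange in the triazolyl diaryl ether series

A few compounds are considered here, and "the series" means these few. Any claim that something is new, unique, unknown or untested is made for them only; others in the source may bear on it.

Measured so far:
compound 1 `CN(C)CCn1cnnc1-c1cc(Oc2ccc(NC(=O)N/N=C/c3c(Cl)cccc3Cl)cc2F)ccn1`: in a functional assay on U-87MG ATCC cells (Homo sapiens) for cytotoxicity, read by MTT assay, with a stated time of 72 h (on this read-out higher numbers stand for weaker inhibition and lower numbers for stronger inhibition), compound 1 gives > 100000 nM, a limit of the assay.
compound 2 `CN(C)CCn1cnnc1-c1cc(Oc2ccc(NC(=O)N/N=C/c3ccc(F)cc3)cc2F)ccn1`: in this assay compound 2 gives 2310 nM.

Going by the values given here, compound 2 holds the only number in this assay; the other value is a limit (the limit of > 100000 nM in this assay, at which 1 of the 2 values shown sits). Among the compounds with values here, the one measured step, an at least 43-fold lower number from compound 1 to compound 2 (1.63 log units; beyond the scatter), shows that exchanging the aryl group on the carbon double-bonded to nitrogen shifts the read-out strongly. Compound 3 `CN(C)CCn1cnnc1-c1cc(Oc2ccc(NC(=O)N/N=C/c3c(O)ccc4ccccc34)cc2F)ccn1` carries 2-hydroxynaphthalen-1-yl in place of 4-fluorophenyl on a carbon with a double bond to nitrogen. The same position is changed again, so a step beyond the scatter is expected, estimated as an 8.7-fold higher number from compound 2 to compound 3 (0.94 log units; beyond the scatter) toward weaker inhibition. Compound 3 is expected at 20000 nM, within 3000 nM to 100000 nM.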

Compound 3, half-maximal inhibitory concentration: 620 nM
Estimate against measurement, compound 3: 32-fold (1.51 log units) above; measured number below the stated range.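

With 2-hydroxynaphthalen-1-yl on the carbon with a double bond to nitrogen, this assay gives a 3.7-fold lower number from compound 2 to compound 3 (0.57 log units; beyond the scatter), so this position accepts an aryl group of two fused rings and does not stop at 4-fluorophenyl. Measured against 2,6-dichlorophenyl, the same group gives an at least 160-fold lower number from compound 1 to compound 3 (2.20 log units; beyond the scatter). The value of compound 1 is a limit, so that step has an open end: the limit of > 100000 nM in this assay, at which 1 of the 3 values shown sits.

Open, on these data alone, is whether the hydroxyl or the second ring carries the change, which plain naphthalen-1-yl would separate. Also open, as far as these compounds go, is how a phenyl bearing an amine or a carboxylic acid behaves at this carbon.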